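A chloro substituent tested on a second core

The compounds below may be only part of what the source reports. "The series", "measured", "known", "first", "only" and "open" are said of these compounds alone.

Compound 1 `COc1cc(-c2nc(-c3ccccc3)[nH]c2-c2ccnc(NCCCNS(=O)(=O)c3ccccc3)n2)ccc1F` is the reference point of this small set. In a functional assay on LOX IMVI cells (Homo sapiens) for cytotoxicity, read by MTT assay, with a stated time of 24 h (a lower number here means a stronger inhibitor, a higher number a weaker inhibitor), compound 1 gives 4520 nM. Compound 2 `COc1cc(-c2nc(-c3ccccc3)[nH]c2-c2ccnc(NCCCNS(=O)(=O)c3ccc(Cl)cc3)n2)ccc1F` differs from compound 1 by chloro in place of hydrogen on an aromatic carbon; in this assay compound 2 gives 83100 nM, and the step between them is an 18-fold higher number from compound 1 to compound 2 (1.26 log units; beyond the scatter). Compound 3 `O=S(=O)(NCCCNc1nccc(-c2[nH]c(-c3ccccc3)nc2-c2ccc(F)c(O)c2)n1)c1ccccc1` differs from compound 1 in its core by hydrogen in place of methyl on an oxygen on an aromatic ring; in this assay compound 3 gives 9580 nM, which is a 2.1-fold higher number from compound 1 to compound 3 (0.33 log units; beyond the scatter). Compound 4 `O=S(=O)(NCCCNc1nccc(-c2[nH]c(-c3ccccc3)nc2-c2ccc(F)c(O)c2)n1)c1ccc(Cl)cc1` has not yet been measured. It differs from compound 3 by chloro in place of hydrogen on an aromatic carbon, the same change that turns compound 1 into compound 2, now made on the core of compound 3. Because the earlier step was an 18-fold higher number from compound 1 to compound 2 (1.26 log units; beyond the scatter), the step expected here is a 9.4-fold higher number from compound 3 to compound 4 (0.97 log units; beyond the scatter), taken a little smaller since that step was seen only once and on a different core. Compound 4 is thus estimated at 90000 nM, with the number expected to fall between 25000 nM and 300000 nM.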

Compound 4, half-maximal inhibitory concentration: 14200 nM
Compound 4: the middle estimate sits 6.3-fold (0.80 log units) above what was measured; the measured number lies below the stated range.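

On the core of compound 3, the chloro substituent gives a much smaller step (a 1.5-fold higher number from compound 3 to compound 4 (0.17 log units; within the scatter)) than it gave on the core of compound 1, so the change does not carry over with the same size: the same change on two cores in this assay, an 18-fold higher number (1.26 log units; beyond the scatter) from compound 1 to compound 2 and a 1.5-fold higher number (0.17 log units; within the scatter) from compound 3 to compound 4, 12-fold (1.09 log units) apart, beyond the scatter of two such steps. Seen from the other side, swapping the methyl on the oxygen for hydrogen among the chlorinated pair (a 5.9-fold lower number from compound 2 to compound 4 (0.77 log units; beyond the scatter)) runs opposite to the same swap without chloro: the same change on two cores in this assay, a 2.1-fold higher number (0.33 log units; beyond the scatter) from compound 1 to compound 3 and a 5.9-fold lower number (0.77 log units; beyond the scatter) from compound 2 to compound 4, 12-fold (1.09 log units) apart, beyond the scatter of two such steps. Within these four compounds, then, the two changes do not act independently, but the numbers do not show why, and a single pair of cores cannot establish a rule for the wider series.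

The compounds shown leave open whether a bromo or a methoxy group at the same ring position would behave like chloro on each core. They also leave open whether either result would persist with a longer chain between the sulfonamide and the amine.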